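This account rests on a few compounds, and the source may have more. Where it says the series, first, only, none or still open, it means among the compounds named here.

Compound 1 `Cc1nc(-c2nc3ccccc3n2Cc2ccccc2)sc1C(=O)O` sits at a limit of a functional assay on MCF7 cells (Homo sapiens) for cytotoxicity, read by MTT assay, with a stated time of 24 h (a higher number here means a weaker inhibitor, a lower number a stronger inhibitor), giving > 20000 nM. Compound 2 `Cc1nc(-c2nc3ccccc3n2Cc2ccccc2)sc1C(=O)Nc1ccccc1` gives 3960 nM and compound 3 `Cc1nc(-c2nc3ccccc3n2Cc2ccccc2)sc1C(=O)NC1CCCCC1` gives 5230 nM; the steps of an at least 5.0-fold lower number from compound 1 to compound 2 (0.70 log units; beyond the scatter) and an at least 3.8-fold lower number from compound 1 to compound 3 (0.58 log units; beyond the scatter) are both beyond the scatter, whereas a 1.3-fold higher number from compound 2 to compound 3 (0.12 log units; within the scatter) is not. Compound 3 thus stands at the higher of the two numbers measured, within the scatter of compound 2. Compound 4 `Cc1nc(-c2nc3ccccc3n2Cc2ccccc2)sc1C(=O)N1CCCCC1` differs from compound 3 in one place: piperidin-1-yl in place of cyclohexylamino on a carbonyl carbon. For the measured compounds named here, no measured step removes the amide hydrogen, and the only step at this nitrogen, a 1.3-fold higher number from compound 2 to compound 3 (0.12 log units; within the scatter), stayed within the scatter. Compound 4 is therefore expected to change little, a 1.2-fold higher number from compound 3 to compound 4 (0.09 log units; within the scatter), with an estimated value of 6500 nM in a range from 2500 nM to 17000 nM.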

Compound 4, half-maximal inhibitory concentration: > 20000 nM
Compound 4: no number, only a limit; the forecaster's own chance of this, stated with the estimate: 12%; middle value at least 3.0-fold (0.48 log units) away from the limit.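

In this assay, the nitrogen on the carbonyl carbon proved sensitive after all: piperidin-1-yl in place of cyclohexylamino gives an at least 3.8-fold higher number from compound 3 to compound 4 (0.58 log units; beyond the scatter), and piperidin-1-yl in place of anilino gives an at least 5.0-fold higher number from compound 2 to compound 4 (0.70 log units; beyond the scatter). Compound 2 and compound 3 both keep the amide hydrogen and lie within the scatter of each other, whereas compound 4 has no such hydrogen. The step from compound 1 to compound 4 cannot be read, because both values are limits: the limit of > 20000 nM in this assay, at which 2 of the 4 values shown sit.

Whether the loss of the hydrogen or the change of ring accounts for the step stays open. An N-methylcyclohexylamino group, which keeps the cyclohexyl ring and lacks that hydrogen, would separate the two.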